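Sulfur for oxygen on the amine nitrogen of compound 1

A few compounds are considered here, and "the series" means these few. Any claim that something is new, unique, unknown or untested is made for them only; others in the source may bear on it.

Among the compounds with values here, in an ADME assay on MDBK cells (Bos taurus) for cytotoxicity, read by MTT assay, with a stated time of 96 h (on this read-out lower numbers stand for higher toxicity in this test and higher numbers for lower toxicity in this test), compound 1 (`COc1ccc(-c2nc3cc(/C(C)=N/NC(N)=O)ccc3n2C2CCCCC2)cc1`) gives 54000 nM, the only true number so far. Compound 2 (`C/C(=N\NC(N)=O)c1ccc2c(c1)nc(-c1ccoc1)n2C1CCCCC1`) reads > 100000 nM, and this value is a limit of the assay, not a number.

Next comes compound 3 (`COc1ccc(-c2nc3cc(/C(C)=N/NC(N)=S)ccc3n2C2CCCCC2)cc1`), which keeps the core of compound 1 and differs only on the amine nitrogen: a group of 3 heavy atoms (1 carbon, 1 nitrogen, 1 sulfur; no ring) in place of a group of 3 heavy atoms (1 carbon, 1 nitrogen, 1 oxygen; no ring), on an amine nitrogen. In words, sulfur takes the place of oxygen, and the atom count of the group stays the same. Within the data shown here, the one measured step, an at least 1.8-fold higher number from compound 1 to compound 2 (0.26 log units; that floor lies within the scatter), sits on an aromatic carbon and not on the amine nitrogen. Among the measured compounds shown here, it therefore gives no size for the present change, and no measured pair yet tests this group. The expectation is thus a cautious one, a moderate move towards a lower number in this assay, held with a wide margin. The expected step is a 2.5-fold lower number from compound 1 to compound 3 (0.39 log units; beyond the scatter). For compound 3 the estimated value is 22000 nM, with an expected range from 7000 nM to 70000 nM.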

Compound 3, half-maximal cytotoxic concentration: 32000 nM
Beside the measured number, compound 3's estimate is 1.5-fold (0.16 log units) below it; low and high end bracket the measured number.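

Sulfur for oxygen on the amine nitrogen now has a measured size in this assay: a 1.7-fold lower number from compound 1 to compound 3 (0.23 log units; within the scatter). That step lies within the scatter, so the carbamoyl group and its sulfur counterpart cannot be told apart on this read-out, and the core of compound 1 tolerates either group on the amine nitrogen without a readable separation. Compound 1 and compound 3 both give true numbers, so this step, unlike the one on the aromatic carbon, rests on two numbers and has no limit on either side.

Still open, as far as these compounds go, is whether a different group in place of the carbamoyl group on the amine nitrogen, such as an acetyl group or a simple methyl group, would give a step beyond the scatter in this assay. Compound 2 gives only a limit and not a number, which leaves the furan-3-yl compound without a true value against which the same sulfur for oxygen change could be sized: the limit of > 100000 nM in this assay, at which 1 of the 3 values shown sits.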